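A few compounds are considered here, and "the series" means these few. Any claim that something is new, unique, unknown or untested is made for them only; others in the source may bear on it.

Measured compounds:
- compound 1, `CCN(CC)CCNC(=O)c1ccc(C(CC)(CC)c2ccc(OCC(O)C(C)(C)C)c(C)c2)n1CC`: 690 nM
- compound 2, `CCn1c(C(=O)N(CCC#N)CCC#N)ccc1C(CC)(CC)c1ccc(OCC(O)C(C)(C)C)c(C)c1`: 480 nM
- compound 3, `C#CC(C)OC(=O)c1ccc(C(CC)(CC)c2ccc(OCC(O)C(C)(C)C)c(C)c2)n1CC`: a limit only, > 50000 nM

The three share one core and differ only in the group on the carbonyl carbon. In a functional assay on MCF7 cells (Homo sapiens), read by MTT assay, with a stated time of 48 h (a higher number here means a weaker inhibitor, a lower number a stronger inhibitor), compound 1 gives 690 nM, the higher of the two plain numbers. Compound 2 gives 480 nM, and the step of a 1.4-fold lower number from compound 1 to compound 2 (0.16 log units; within the scatter) stays within the scatter. Compound 3 reaches only a limit of the assay, > 50000 nM (the limit of > 50000 nM in this assay, at which 1 of the 3 values shown sits). The steps of an at least 72-fold higher number from compound 1 to compound 3 (1.86 log units; beyond the scatter) and an at least 100-fold higher number from compound 2 to compound 3 (2.01 log units; beyond the scatter) are both large.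

Compound 4, `CC[C@@H](C)[C@H](NC(=O)c1ccc(C(CC)(CC)c2ccc(OCC(O)C(C)(C)C)c(C)c2)n1CC)C(=O)O`, differs from compound 1 by 1-carboxy-2-methylbutyl in place of 2-(diethylamino)ethyl on an amide-type nitrogen. The amide-type nitrogen is kept, as in compound 1 and compound 2, while compound 3 carries (1-methylprop-2-yn-1-yl)oxy in place of (2-(diethylamino)ethyl)amino. Among the compounds with values here, the two measured amides lie within the scatter of each other, but no measured compound carries a 1-carboxy-2-methylbutyl group, so the size of its effect is unknown. A modest weakening is expected, a 2.2-fold higher number from compound 1 to compound 4 (0.34 log units; beyond the scatter). Compound 4 is estimated at 1500 nM, between 400 nM and 8000 nM.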

Compound 4, half-maximal inhibitory concentration: 2000 nM
Compound 4: the middle estimate sits 1.3-fold (0.12 log units) below what was measured; low and high end bracket the measured number.
By their numbers in this assay, from the lowest: compounds 2 and 1 (each within the scatter of the next); then compound 4. At a limit, above all of these: compound 3.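

The 1-carboxy-2-methylbutyl group shows that the group on this amide-type nitrogen can shift the number beyond the scatter, which the two earlier amides did not show: a 2.9-fold higher number from compound 1 to compound 4 (0.46 log units; beyond the scatter) and a 4.2-fold higher number from compound 2 to compound 4 (0.62 log units; beyond the scatter) are both modest steps. Even so, all three nitrogen-linked groups stay far from the oxygen-linked group of compound 3, as an at least 25-fold lower number from compound 3 to compound 4 (1.39 log units; beyond the scatter) shows for this newest amide. That step is only a bound, since compound 3 sits at a limit rather than a number: the limit of > 50000 nM in this assay, at which 1 of the 4 values shown sits.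

In compound 4 the diethylamino group leaves and the carboxylic acid enters in one change, so the compounds shown do not separate the two; a plain 2-methylbutyl chain on the same nitrogen would. A single oxygen-linked group also leaves open whether a simple methyl ester or the free carboxylic acid on the carbonyl carbon would behave like compound 3.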